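Isopropyl in Place of Nitro on the Aryl Ring

This account rests on a few compounds, and the source may have more. Where it says the series, first, only, none or still open, it means among the compounds named here.

Compound 1, `CC1=C(C(=O)OCC2CCN(C(=O)OC(C)(C)C)CC2)[C@@H](c2cccc(Br)c2)C2=C(CC(C)(C)CC2=O)N1`, in an assay on HEK293 cells for inhibition of neurogenic locus notch homolog protein 1 (Homo sapiens), read by a luciferase reporter and resazurin assay, with a stated time of 16 h; on this read-out higher numbers stand for weaker inhibition and lower numbers for stronger inhibition: 2590 nM.
Compound 2, `CC1=C(C(=O)OCCC2CCN(C(=O)OC(C)(C)C)CC2)C(c2cccc(Br)c2)C2=C(CC(C)(C)CC2=O)N1`, in this assay: 2950 nM.
Compound 3, `CC1=C(C(=O)OCC2CCN(C(=O)OC(C)(C)C)CC2)C(c2cccc([N+](=O)[O-])c2)C2=C(CC(C)(C)CC2=O)N1`, in this assay: > 10000 nM, which is a limit of the assay and not a number.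

Compound 3 thus stands at the weak end of what is shown: its result is only a limit (the limit of > 10000 nM in this assay, at which 1 of the 3 values shown sits), whereas compound 1 and compound 2, which carry a bromine substituent on that ring instead of the nitro group, give numbers. Compound 4, `CC1=C(C(=O)OCC2CCN(C(=O)OC(C)(C)C)CC2)C(c2cccc(C(C)C)c2)C2=C(CC(C)(C)CC2=O)N1`, is yet to be measured. It differs from compound 3 by isopropyl in place of nitro on an aromatic carbon. For the measured compounds named here, no measured pair shows this change. With compound 3 at a limit, the size of the step cannot be fixed, but a move toward stronger inhibition in this assay beyond the scatter is expected, since compound 1 and compound 2 without the nitro group give numbers within reach. Compound 4 is therefore estimated at 4000 nM, with a range from 1500 nM to 10000 nM. The expected step is an at least 2.5-fold lower number from compound 3 to compound 4 (0.39 log units; beyond the scatter).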

Compound 4, half-maximal inhibitory concentration: 3320 nM
For compound 4 the middle estimate is 1.2-fold (0.08 log units) above the measured one, and the stated range covers the measured number.
By their numbers in this assay, from the lowest: compounds 1, 2 and 4 (each within the scatter of the next). At a limit, above all of these: compound 3.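

In this assay the swap of nitro for isopropyl gives an at least 3.0-fold lower number from compound 3 to compound 4 (0.47 log units; beyond the scatter), the first step read for the change from 3-nitrophenyl to 3-isopropylphenyl. Until now only bromine had given a number on this ring, but isopropyl gives one too: compound 4 at 3320 nM lies within the scatter of compound 1 at 2590 nM. The step can be given only as a bound, and compound 3 holds the one result of this kind: the limit of > 10000 nM in this assay, at which 1 of the 4 values shown sits.

On these data alone, how far the nitro result lies from the others stays open, as does whether isopropyl would give a similar result on the longer chain of compound 2. The compounds shown also leave open how an amine, a carboxylic acid or a methoxy group on this aromatic carbon would read in this assay.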